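The source may hold more compounds than are shown below. What is called first, only, known or untested is meant among the compounds shown, and "the series" means these compounds.

In an assay on isolated protein (strain Sprague-Dawley) for inhibition of Amine oxidase [flavin-containing] A (Rattus norvegicus), read by spectrophotometry, with a stated time of 5 min, tested at 10 uM (on this read-out higher numbers stand for more inhibition at the one concentration tested (going by the name of the read-out) and lower numbers for less inhibition), three compounds built on one shared core have been measured. Compound 1 `CC(C)Oc1cc(=O)oc2cc(OCc3cccc(Cl)c3)ccc12` gives 3%, compound 2 `CC(=O)COc1cc(=O)oc2cc(OCc3cccc(Cl)c3)ccc12` gives 22%, and compound 3 `CCOC(=O)Nc1cc(=O)oc2cc(OCc3cccc(Cl)c3)ccc12` gives 21%. Compound 3 stands second highest of the three numbers. The step of a number 1 percentage points lower from compound 2 to compound 3 (within the scatter) lies within the scatter, whereas the step of a number 18 percentage points higher from compound 1 to compound 3 (beyond the scatter) lies beyond it, so compound 3 is separated from compound 1 but not from compound 2.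

Compound 4 `O=C(O)c1cc(=O)oc2cc(OCc3cccc(Cl)c3)ccc12` has not yet been measured. It differs from compound 3 in one place: carboxy in place of (ethoxycarbonyl)amino on an aromatic carbon. The measured steps that bear on this change are those that exchange the group on the same aromatic carbon. The steps of a number 19 percentage points higher from compound 1 to compound 2 (beyond the scatter) and a number 18 percentage points higher from compound 1 to compound 3 (beyond the scatter) show that such an exchange can shift the number by a modest amount, while the step of a number 1 percentage points lower from compound 2 to compound 3 (within the scatter) shows two different groups at that carbon giving the same number. Among the compounds with values here, no measured step puts a carboxy at this carbon, so the direction of the change is not fixed by these data. Compound 4 is therefore expected to stay close to compound 3. The estimated step is a number 6 percentage points lower from compound 3 to compound 4 (within the scatter), within the scatter. Compound 4 is expected to give 15%, with a range from 0% to 35%.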

Compound 4, a percentage reported as inhibition, at one concentration (the size of the read-out at that concentration, not a potency): 0%
Compound 4: middle estimate off by 15 percentage points, on the high side; the measured number falls inside the stated range.
By their numbers in this assay, from the lowest: compounds 4 and 1 (each within the scatter of the next); then compounds 3 and 2 (each within the scatter of the next).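

In this assay, the carboxy group at this aromatic carbon, opposite the ring oxygen, does not share the level of the (ethoxycarbonyl)amino and 2-oxopropoxy groups, with steps of a number 21 percentage points lower from compound 3 to compound 4 (beyond the scatter) and a number 22 percentage points lower from compound 2 to compound 4 (beyond the scatter) instead matching the isopropoxy group, as a number 3 percentage points lower from compound 1 to compound 4 (within the scatter) shows. The earlier compounds shown here showed two groups giving matching numbers and one group lying apart from them; compound 4 adds that holding a carbonyl, as the (ethoxycarbonyl)amino, 2-oxopropoxy and carboxy groups all do, is not enough on its own to reach the level of compound 2 and compound 3 at this carbon. Nothing available here accounts for this split among the four groups.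

As far as these compounds go, what remains open is whether the low number belongs to the free carboxylic acid itself, which an ethyl ester or a primary amide at the same carbon would help to separate from the rest of the group. From the compounds shown here alone, it is also open whether a primary amine or a longer chain ending in a ketone would stay at the level of compound 2 and compound 3 or rise above it.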